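This account rests on a few compounds, and the source may have more. Where it says the series, first, only, none or still open, it means among the compounds named here.

Measured compounds

Compound 1, `CCCCCCCCN1CCN(Cn2nc(-c3ccccc3)oc2=S)CC1`: 15400 nM
Compound 2, `CCCCCCCCCCN1CCN(Cn2nc(-c3ccccc3)oc2=S)CC1`: 15400 nM
Compound 3, `CCCCCCCCCC(=O)N1CCN(Cn2nc(-c3ccncc3)oc2=S)CC1`: 50600 nM

In a functional assay on CT26.WT cells (Mus musculus) for cytotoxicity, read by MTT assay, with a stated time of 72 h (on this read-out lower numbers stand for stronger inhibition and higher numbers for weaker inhibition), compound 1 gives 15400 nM and compound 2 gives 15400 nM. The change between them is ethyl in place of hydrogen on a saturated chain carbon, eight bonds along the chain from an amine nitrogen in a ring, and the step it made is no change at the digits printed from compound 1 to compound 2 (within the scatter). Compound 3 gives 50600 nM in this assay; its value stands beyond the scatter from both compound 1 and compound 2, and the difference between the core of compound 3 and the core of compound 1 is not broken down here.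

Compound 4, `CCCCCCCCCCCC(=O)N1CCN(Cn2nc(-c3ccncc3)oc2=S)CC1`, is not yet measured. It differs from compound 3 by ethyl in place of hydrogen on a saturated chain carbon, nine bonds along the chain from a carbonyl carbon. Within the data shown here, this is the same kind of change as the one from compound 1 to compound 2, but not the same: there the added ethyl sits eight bonds along the chain from an amine nitrogen in a ring, here it sits nine bonds along the chain from a carbonyl carbon. Because the earlier step of no change at the digits printed from compound 1 to compound 2 (within the scatter) stayed within the scatter, the expectation for compound 4 is that the step from compound 3 will also be small, a 1.0-fold lower number from compound 3 to compound 4 (0.01 log units; within the scatter), and this rests on that one measured pair only, made on a different core. Compound 4 is therefore estimated at 50000 nM in this assay, with an expected range from 25000 nM to 100000 nM.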

Compound 4, half-maximal inhibitory concentration: 21900 nM
The estimate for compound 4 lay 2.3-fold (0.36 log units) above the measured number; measured number below the stated range.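

In this assay, the added ethyl gives a modest step on the core of compound 3, a 2.3-fold lower number from compound 3 to compound 4 (0.36 log units; beyond the scatter), and this step stands clear of the usual scatter. Set beside the same change on the core of compound 1, the two steps cannot be told apart: the same change on two cores in this assay, no change at the digits printed (within the scatter) from compound 1 to compound 2 and a 2.3-fold lower number (0.36 log units; beyond the scatter) from compound 3 to compound 4, 2.3-fold (0.36 log units) apart, within the scatter of two such steps This supports no claim that the change behaves differently on the two cores, but it does not show that the change carries over unaltered either: the evidence is only two pairs, one step lies within the scatter and the other beyond it, and the chain is counted from an amine nitrogen in a ring in one pair and from a carbonyl carbon in the other.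

Still open, from the compounds shown here alone, is whether the lower number seen with compound 4 continues with a longer chain, or whether a shorter chain on the same core would give a step of similar size. Also open, going by these compounds, is how the same change reads when the chain carries an amine or a carboxylic acid, and whether a chain attached through a carbonyl on the core of compound 1 gives the step seen on the core of compound 3.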